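Gem-dimethyl extension of the triazole side chain toward compound 3

The compounds below may be only part of what the source reports. "The series", "measured", "known", "first", "only" and "open" are said of these compounds alone.

Measured compounds:
Compound 1 `CC(O)c1cn(CCNc2nonc2/C(=N/O)Nc2ccc(F)c(Br)c2)nn1`: 362 nM
Compound 2 `OCCOCc1cn(CCNc2nonc2/C(=N/O)Nc2ccc(F)c(Br)c2)nn1`: 144 nM

In an assay on isolated protein for inhibition of Indoleamine 2,3-dioxygenase 2 (Homo sapiens) (on this read-out lower numbers stand for stronger inhibition and higher numbers for weaker inhibition), compound 2 gives 144 nM and stands at the lowest number of the two measured, with compound 1 as its nearest neighbour at 362 nM; the gap is a 2.5-fold lower number from compound 1 to compound 2 (0.40 log units; beyond the scatter). Compound 3 `CC(C)(OCCO)c1cn(CCNc2nonc2/C(=N/O)Nc2ccc(F)c(Br)c2)nn1` has not yet been measured. It differs from compound 2 by 1-(2-hydroxyethoxy)-1-methylethyl in place of (2-hydroxyethoxy)methyl on an aromatic carbon. For the measured compounds named here, only one measured step touches this position, a 2.5-fold lower number from compound 1 to compound 2 (0.40 log units; beyond the scatter), and it swaps a different group, so it shows that the assay responds to what sits there, but gives no direct reading for the two added methyls. Compound 3 is therefore expected to land near compound 2, with a step of a 1.3-fold higher number from compound 2 to compound 3 (0.10 log units; within the scatter) that need not exceed the scatter. The estimate for compound 3 in this assay is 180 nM, within 70 nM to 500 nM.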

Compound 3, half-maximal inhibitory concentration: 1170 nM
Compound 3: middle estimate off by 6.5-fold (0.81 log units), on the low side; the measured number lies above the stated range.
By their numbers in this assay, from the lowest: compound 2; then compound 1; then compound 3.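

In this assay, for the compounds shown here, the earlier pair showed only that the group on this aromatic carbon matters; the new result shows that the substitution on the carbon joining the 2-hydroxyethoxy chain to the ring matters as well, since the gem-dimethyl change gives an 8.1-fold higher number from compound 2 to compound 3 (0.91 log units; beyond the scatter). The 2-hydroxyethoxy chain alone therefore does not secure the lower number, and the 1-(2-hydroxyethoxy)-1-methylethyl group also compares unfavourably with 1-hydroxyethyl, with a 3.2-fold higher number from compound 1 to compound 3 (0.51 log units; beyond the scatter). Nothing available here accounts for this rise.

The compounds shown leave open whether a single added methyl or a cyclopropyl ring at that carbon would give a number closer to that of compound 2 or compound 3. They also leave open how an amine or a carboxylic acid in place of the terminal hydroxyl would read.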